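A Trifluoromethyl Swap on the Shared Core

The source may report more compounds than this note shows. Statements on the series, on what has been measured and on what is new or still open speak of the compounds shown alone.

In an ADME assay on SW1353 cells (Homo sapiens) for cytotoxicity, read by a luciferase reporter, with a stated time of 30 min (a higher number here means that more compound is tolerated, a lower number that less compound is tolerated), compound 1 (`O=C(Nc1ccc(N2CCNCC2)cc1)c1ccc(-c2ccccc2Cl)o1`) reads 15000 nM and compound 2 (`O=C(Nc1ccc(N2CCNCC2)cc1)c1ccc(-c2ccc(Cl)cc2Cl)o1`) reads 8100 nM, while compound 3 (`Cc1cc(Cl)ccc1-c1ccc(C(=O)Nc2ccc(N3CCNCC3)cc2)o1`) reads 8800 nM and so lies within the scatter of both. Compound 4 (`O=C(Nc1ccc(N2CCNCC2)cc1)c1ccc(-c2ccc(C(F)(F)F)cc2)o1`) has 4-(trifluoromethyl)phenyl in place of 4-chloro-2-methylphenyl on an aromatic carbon. For the measured compounds named here, no measured compound carries trifluoromethyl, so only the nearest steps can guide the expectation. Those steps are a 1.9-fold lower number from compound 1 to compound 2 (0.27 log units; within the scatter) and a 1.7-fold lower number from compound 1 to compound 3 (0.23 log units; within the scatter) and also a 1.1-fold higher number from compound 2 to compound 3 (0.04 log units; within the scatter) and all three stay small. For this assay no step beyond the scatter is therefore expected, and the estimated step is a 1.0-fold higher number from compound 3 to compound 4 (0.01 log units; within the scatter) here. The estimate for compound 4 is 9000 nM (expected range 4000 nM to 20000 nM).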

Compound 4, half-maximal cytotoxic concentration: > 15000 nM
Compound 4 ended at the assay's limit; the forecaster's own chance of this, stated with the estimate: 8%; middle value at least 1.6-fold (0.22 log units) away from the limit.
By their numbers in this assay, from the lowest: compounds 2, 3 and 1 (each within the scatter of the next).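

In this assay compound 4 reads > 15000 nM, which is a limit of the assay and not a number: the limit of > 15000 nM in this assay, at which 1 of the 4 values shown sits. The two readable steps, an at least 1.7-fold higher number from compound 3 to compound 4 (0.23 log units; that floor lies within the scatter) and an at least 1.8-fold higher number from compound 2 to compound 4 (0.26 log units; that floor lies within the scatter), give only floors within the scatter. Thus 4-(trifluoromethyl)phenyl, the first group here without chloro, shows no sign of less compound being tolerated, while the third step of a number no lower from compound 1 to compound 4 (the limit leaves the size open) cannot be read. As far as these compounds go, the true size of all three steps stays open. So does the reading for an amine or a carboxylic acid in place of trifluoromethyl.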